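One chain change from compound 2 to compound 3

This account rests on a few compounds, and the source may have more. Where it says the series, first, only, none or still open, it means among the compounds named here.

Measured so far in a functional assay on HepG2 cells (Homo sapiens) for inhibition, read by MTT assay, with a stated time of 48 h; a higher number here means a weaker inhibitor, a lower number a stronger inhibitor:
Compound 1 `COc1ccc(N(C)c2nc(C)nc3ccccc23)cc1C(=O)OCCCC[Se]C#N` gives 975 nM
Compound 2 `COc1ccc(N(C)c2nc(C)nc3ccccc23)cc1OCCCC[Se]C#N` gives 6460 nM

Of these two numbers, compound 2 at 6460 nM stands highest, which makes it the weaker inhibitor of the pair. Compound 3 `COc1ccc(N(C)c2nc(C)nc3ccccc23)cc1OCCCCC[Se]C#N` has not yet been measured. Its structure departs from that of compound 2 by a group of 4 heavy atoms (2 carbon, 1 nitrogen, 1 selenium; no ring) in place of a group of 3 heavy atoms (1 carbon, 1 nitrogen, 1 selenium; no ring), on a saturated chain carbon, four bonds along the chain from an oxygen on an aromatic ring and in no other way.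

Among the measured compounds shown here, only one measured step is available, namely a 6.6-fold higher number from compound 1 to compound 2 (0.82 log units; beyond the scatter) on the numbers so far. That step is beyond the scatter, but it replaces a group on an aromatic carbon and does not isolate a change at the saturated chain carbon. For the measured compounds named here, it therefore bears on the new change only indirectly, and no measured pair shows this change alone. As far as these compounds go, on that limited evidence, no step beyond the scatter is expected in this assay and the direction remains open. The expected step is a 1.3-fold lower number from compound 2 to compound 3 (0.11 log units; within the scatter) by this estimate. For compound 3 the estimated value is 5000 nM with an expected range from 1900 nM to 13000 nM for the coming measurement.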

Compound 3, half-maximal inhibitory concentration: 5210 nM
Compound 3: the middle estimate sits 1.0-fold (0.02 log units) below what was measured; the measured number falls inside the stated range.
By their numbers in this assay, from the lowest: compound 1; then compounds 3 and 2 (each within the scatter of the next).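

In this assay, putting the group of 4 heavy atoms in place of the group of 3 heavy atoms, on a saturated chain carbon, four bonds along the chain from an oxygen on an aromatic ring, gives a 1.2-fold lower number from compound 2 to compound 3 (0.09 log units; within the scatter), so this change at this place cannot be told apart from repeat-measurement noise. The earlier pair spoke only to a change on an aromatic carbon, whereas this pair isolates the chain itself and shows that the gap to compound 1 persists with the new group, at a 5.3-fold higher number from compound 1 to compound 3 (0.73 log units; beyond the scatter), a step beyond the scatter and of about the size seen before. Nothing measured alongside these numbers accounts for either the flat chain step or the persisting gap.

The compounds shown leave open whether a longer chain at the same place would stay equally flat, or whether an amine or a carboxylic acid at the chain end would move the number beyond the scatter. They also leave open whether the same chain change would behave alike in the carbonyl-bearing series of compound 1.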